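A Bromoalkenyl Chain in Place of Butyl on the Amide

This account rests on a few compounds, and the source may have more. Where it says the series, first, only, none or still open, it means among the compounds named here.

Measured so far:
Compound 1, `CCCCC(=O)N(Cc1ccc(OC)c(O)c1)c1cc(OC)c(OC)c(OC)c1`: 66 nM in a functional assay on MGC-803 cells (Homo sapiens) for inhibition, read by MTT assay, with a stated time of 48 h; a higher number here means a weaker inhibitor, a lower number a stronger inhibitor.
Compound 3, `COc1ccc(N(Cc2cc(OC)c(OC)c(OC)c2)C(=O)CCl)cc1O`: 24500 nM in this assay.
Compound 2, `COc1cc(NCc2ccc(Br)cc2)cc(OC)c1OC`: the assay returned only its limit, > 80000 nM.

Among the two numbers at hand, compound 1 has the lowest, that is, it is the stronger inhibitor; the nearest number, from compound 3, is far higher, well beyond the usual scatter. The value for compound 2 is a limit and not a number (the limit of > 80000 nM in this assay, at which 1 of the 3 values shown sits).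

Compound 4, `COc1ccc(CN(C(=O)/C=C/CBr)c2cc(OC)c(OC)c(OC)c2)cc1O`, keeps the core of compound 1 and changes only the acyl chain on the amide: 3-bromoprop-1-en-1-yl in place of butyl on a carbonyl carbon. Within the data shown here, no pair of already measured compounds differs by this kind of change, so there is no measured step to lean on. A modest loss of potency is expected, the step of a 4.5-fold higher number from compound 1 to compound 4 (0.66 log units; beyond the scatter) lying somewhat beyond the scatter. Compound 4 is therefore estimated at 300 nM, within a range from 40 nM to 3000 nM.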

Compound 4, half-maximal inhibitory concentration: 71 nM
The estimate for compound 4 lay 4.2-fold (0.63 log units) above the measured number; measured number inside the range.
By their numbers in this assay, from the lowest: compounds 1 and 4 (each within the scatter of the next); then compound 3. At a limit, above all of these: compound 2.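

Among these compounds, this is the first measured step at this position, the acyl chain on the amide, since the earlier compounds offered no pair differing in one place. In this assay, placing 3-bromoprop-1-en-1-yl in place of butyl on a carbonyl carbon gives a 1.1-fold higher number from compound 1 to compound 4 (0.03 log units; within the scatter), so the two chains cannot be told apart here, even though the new chain brings a bromine and a double bond to a position that held a plain butyl. Nothing measured here explains why the two chains read alike.

From the compounds shown here alone, how the bromine and the double bond each count on their own stays open, since both enter in the same step. Also open, going by these compounds, is how a longer chain, or a chain ending in an amine or a carboxylic acid, would read at this position on the core of compound 1.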